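Acylsulfonamide series: side-chain amide replaced by carbamoyl group

The source may report more compounds than this note shows. Statements on the series, on what has been measured and on what is new or still open speak of the compounds shown alone.

The shared core carries an acylsulfonamide arm. Compound 1 `CCS(=O)(=O)NC(=O)c1ccc(Nc2nc(NC3(c4ccc(Cl)cc4)CC3)nc(OCC(F)(F)F)n2)cc1` ends this arm as a plain ethyl group; in an ADME assay on microsomes from liver (Rattus norvegicus) for metabolic stability, with a stated time of 10 min (on this read-out higher numbers stand for a more stable compound and lower numbers for a less stable compound), compound 1 gives 85%. Within the data shown here, compound 2 `O=C(NS(=O)(=O)CCNC(=O)C1CC1)c1ccc(Nc2nc(NC3(c4ccc(Cl)cc4)CC3)nc(OCC(F)(F)F)n2)cc1` extends the arm by a (cyclopropylcarbonyl)amino group; in this assay compound 2 is reported as "not active" (no number reported), so no single number stands for it, and no step from compound 1 to compound 2 can be sized.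

Compound 3 `CC(C)NC(=O)NCCS(=O)(=O)NC(=O)c1ccc(Nc2nc(NC3(c4ccc(Cl)cc4)CC3)nc(OCC(F)(F)F)n2)cc1` is the next member to be measured. Its difference from compound 2 is isopropylamino in place of cyclopropyl on a carbonyl carbon; read one bond further out, this is (cyclopropylcarbonyl)amino to (isopropylcarbamoyl)amino. Among the measured compounds shown here, with compound 2 lacking a number, no step to compound 3 can be stated and no direction is known; the only anchor is compound 1 in this assay with 85%. Compound 3 is therefore expected to fall in this assay at about 70%, with a range from 40% to 95%, and a fair chance that, like compound 2, only a qualifier and no number is returned.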

Compound 3, percent of the compound remaining: 97%
Estimate against measurement, compound 3: 27 percentage points below; measured number outside the range, above it.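

In this assay the arm of the shared core turns out to tolerate substitution at this position: (isopropylcarbamoyl)amino in place of hydrogen on a saturated chain carbon, two bonds along the chain from a sulfonyl sulfur, gives a number 12 percentage points higher from compound 1 to compound 3 (beyond the scatter) and a modest step beyond the scatter, so an extended arm need not cost anything on this read-out. The swap of cyclopropyl for isopropylamino on the carbonyl carbon cannot be sized, since compound 2 carries only a qualifier; all that can be said is that compound 3 gives 97% as a plain number, and any step involving compound 2 cannot be read. Nothing at hand bears on what lies behind the higher number for compound 3. With only compound 1 and compound 3 as numbered points, no trend along the arm can be drawn. Still open, on these data alone, is whether the number holds with a longer chain ahead of the (isopropylcarbamoyl)amino group, or with a carboxylic acid or a primary amine ending the arm instead.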